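Cyclohexyl for propyl on the chain carbon: expected cytotoxicity

This account rests on a few compounds, and the source may have more. Where it says the series, first, only, none or still open, it means among the compounds named here.

Measured compounds:
compound 1 `CCC[C@H](CCn1cncn1)c1ccccc1`, 63.1 ug/mL
compound 2 `CCC[C@H](CCn1cncn1)c1ccc(C)cc1`, 47.2 ug/mL
compound 3 `CCC[C@H](CCn1cncn1)c1ccc(OC)cc1`, 59.3 ug/mL

In an ADME assay on RD cells (Homo sapiens) for cytotoxicity, read by MTT assay, with a stated time of 3 days (on this read-out lower numbers stand for higher toxicity in this test and higher numbers for lower toxicity in this test), compound 1 gives the highest of the three numbers, though the spread is small: a 1.3-fold lower number from compound 1 to compound 2 (0.13 log units; within the scatter) and a 1.1-fold lower number from compound 1 to compound 3 (0.03 log units; within the scatter). Between the two substituted analogues the gap is likewise small, a 1.3-fold higher number from compound 2 to compound 3 (0.10 log units; within the scatter), so nothing among the three can be set apart.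

Compound 4 `c1ccc([C@@H](CCn2cncn2)C2CCCCC2)cc1` differs from compound 1 in one place: cyclohexyl in place of propyl on a saturated chain carbon bound to an aromatic carbon and a saturated chain carbon. Going by the values given here, none of the measured steps touches this position; all three concern substituents on the aromatic ring, and each stayed within the scatter. Among the compounds with values here, there is therefore no measured precedent for the step to compound 4, and the only available guide is that the series so far has been flat.

On that basis the step is expected to be small, a 1.3-fold lower number from compound 1 to compound 4 (0.10 log units; within the scatter), with no direction favoured beyond the scatter. For compound 4 the estimate in this assay is 50 ug/mL, in the range 25 ug/mL to 100 ug/mL.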

Compound 4, half-maximal cytotoxic concentration: 9.2 ug/mL
For compound 4 the middle estimate is 5.4-fold (0.74 log units) above the measured one, outside the stated range (below it).
By their numbers in this assay, from the lowest: compound 4; then compounds 2, 3 and 1 (each within the scatter of the next).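

In this assay, going by these compounds alone, this saturated chain carbon is the first place where a change moves the number beyond the scatter (a 6.9-fold lower number from compound 1 to compound 4 (0.84 log units; beyond the scatter)), whereas the methyl and methoxy steps on the aromatic ring all stayed within it. The change is all carbon, with no hydrogen-bond donors or acceptors on either side, so a carbon-only group at this position is enough to give a lower number in this test. No measurement shown accounts for the step.

As far as these compounds go, it remains open whether the step goes with the ring itself or with the larger carbon count, which a hexyl chain or a cyclopentyl group at this carbon would help to separate. Also open, from the compounds shown here alone, is whether methyl or methoxy on the aromatic ring stays as flat with cyclohexyl in place of propyl.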